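Two quinazoline pairs differing by a single ring fluorine

The source may report more compounds than this note shows. Statements on the series, on what has been measured and on what is new or still open speak of the compounds shown alone.

Compound 1 `CCCCNc1nc(NCc2ccco2)c2ccccc2n1` and compound 2 `CCCCNc1nc(NCc2ccco2)c2cc(F)ccc2n1` share one core, the only difference being (hydrogen in place of fluoro on an aromatic carbon). In a functional assay on HT-29 cells (Homo sapiens) for cytotoxicity, read by MTT assay, with a stated time of 2 days (a lower number here means a stronger inhibitor, a higher number a weaker inhibitor), compound 1 gives 2940 nM, and compound 2 gives 3040 nM, so the step of a 1.0-fold lower number from compound 2 to compound 1 (0.01 log units; within the scatter) is small. Compound 3 `CCN(CC)CCNc1nc(NCc2ccco2)c2cc(F)ccc2n1` carries the same fluoro, but its side chain differs from that of compound 2 by diethylamino in place of ethyl on a saturated chain carbon, two bonds along the chain from a nitrogen on an aromatic ring; in this assay compound 3 gives "not determined" (no result reported), so no number is reported for it. Compound 4 `CCN(CC)CCNc1nc(NCc2ccco2)c2ccccc2n1` differs from compound 3 by hydrogen in place of fluoro on an aromatic carbon, the same change that turns compound 2 into compound 1. Since compound 3 has no value, compound 4 is estimated alone: it is expected near 3000 nM, within 700 nM to 13000 nM, because compound 1 gives 2940 nM and the side-chain change has no measured effect here.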

Compound 4, half-maximal inhibitory concentration: 10300 nM
For compound 4 the middle estimate is 3.4-fold (0.54 log units) below the measured one; measured number inside the range.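

In this assay, diethylamino in place of ethyl on the side chain gives a 3.5-fold higher number from compound 1 to compound 4 (0.54 log units; beyond the scatter), a modest weakening on the core without fluoro. On these data alone, the matching steps that involve compound 3 cannot be read, so whether this change carries over to the fluoro core remains unknown, and one reading on one core cannot establish transfer. Nothing shown explains the size of this step.

As far as these compounds go, whether a dimethylamino group or a morpholine ring at the end of the side chain would give a similar number remains open. So does whether chloro in place of fluoro would matter on either core.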